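The compounds below may be only part of what the source reports. "The series", "measured", "known", "first", "only" and "open" are said of these compounds alone.

Measured in a functional assay on ileum (Cavia porcellus) for antagonist activity, with a stated time of 30 s; a higher number here means a weaker inhibitor, a lower number a stronger inhibitor

Compound 1 `O=C(O)c1cc(=O)c2ccc(OCCCCCc3ccccc3)cc2o1` gives 0.6 ug/mL
Compound 2 `O=C(O)c1cc(=O)c2ccc(OCCCCCOc3cccc(O)c3)cc2o1` gives 1.5 ug/mL
Compound 3 `COc1cccc(OCCCCCOc2ccc3c(=O)cc(C(=O)O)oc3c2)c1` gives 1.5 ug/mL

Compound 3 shares the highest of the three numbers with compound 2, and the two stand level (no change at the digits printed from compound 2 to compound 3 (within the scatter)). Compound 1 has the lowest number, and the gap to it is modest (a 2.5-fold higher number from compound 1 to compound 3 (0.40 log units; beyond the scatter)).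

The next compound, compound 4 `CC(=O)c1ccc(OCCCCCOc2ccc3c(=O)cc(C(=O)O)oc3c2)cc1O`, differs from compound 3 only at the far end of the chain (4-acetyl-3-hydroxyphenyl in place of 3-methoxyphenyl on an oxygen on a saturated carbon), with 4-acetyl-3-hydroxyphenyl in place of 3-methoxyphenyl on an oxygen on a saturated carbon. Two kinds of measured step bear on this. Methyl in place of hydrogen on the oxygen of that end ring changed nothing (no change at the digits printed from compound 2 to compound 3 (within the scatter)). Exchanging the whole end group, phenyl for 3-hydroxyphenoxy, gave only a modest step (a 2.5-fold higher number from compound 1 to compound 2 (0.40 log units; beyond the scatter)). Within the data shown here, none of the three compounds goes against the reading that this end of the molecule moves this assay little, but no measured compound carries an acetyl group, so that part of the change is untested.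

No step beyond the scatter is therefore expected, and no direction can be argued with confidence. For compound 4 the estimated value is 1.2 ug/mL, with an expected range from 0.4 ug/mL to 3.5 ug/mL in this read-out. This estimate means an expected 1.3-fold lower number from compound 3 to compound 4 (0.10 log units; within the scatter) in all.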

Compound 4, half-maximal inhibitory concentration: 6.8 ug/mL
Compound 4: the middle estimate sits 5.7-fold (0.75 log units) below what was measured; measured number outside the range, above it.
By their numbers in this assay, from the lowest: compound 1; then compounds 2 and 3 (each within the scatter of the next); then compound 4.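

In this assay, among these compounds, the far end of the chain proves less inert than the earlier compounds suggested: acetyl in place of hydrogen on an aromatic carbon of the end ring gives a 4.5-fold higher number from compound 2 to compound 4 (0.66 log units; beyond the scatter), a step toward a weaker inhibitor, whereas methyl on the oxygen of that ring changed nothing beyond the scatter. The full exchange of 3-methoxyphenyl for 4-acetyl-3-hydroxyphenyl gives a step of the same size, a 4.5-fold higher number from compound 3 to compound 4 (0.66 log units; beyond the scatter), so at the digits printed, the end ring's oxygen carrying hydrogen or methyl makes no difference to the size of the step to compound 4. The data shown offer no measured explanation for this loss.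

As far as these compounds go, it remains open whether the step belongs to the acetyl group specifically or would also appear with another group on that aromatic carbon, such as chlorine, a primary amide or a propionyl group. Also unresolved is whether an acetyl group would have the same effect with a shorter or longer chain, or on an end ring lacking the hydroxyl group.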